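The compounds below may be only part of what the source reports. "The series", "measured", "known", "first", "only" and "open" are said of these compounds alone.

Measured compounds:
compound 1, `CC(=O)OCc1ccc2oc(=O)c(C(=O)Sc3ccccc3)cc2c1`, 83.5%
compound 2, `CC(=O)OCc1ccc2oc(=O)c(C(=O)Nc3cccc(Cl)c3)cc2c1`, 66.9%
compound 3, `CCCCCCC(=O)OCc1ccc2oc(=O)c(C(=O)Oc3cccc(Br)c3)cc2c1`, 55.6%

All three numbers come from a functional assay on HT-1080 cells (Homo sapiens), read by transwell migration, with a stated time of 24 h, tested at 1 uM; a lower number here means a stronger effect, a higher number a weaker effect of the compound at the concentration tested. Compound 3 stands lowest of the three: compound 2 lies a number of points higher, and compound 1 higher still, both gaps beyond the scatter. Within the data shown here, the one step recorded between two measured compounds, a number 16.6 percentage points lower from compound 1 to compound 2 (beyond the scatter), concerns the group on the carbonyl carbon and is modest in size.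

Compound 4, `NCc1ccc2oc(=O)c(C(=O)Oc3cccc(Br)c3)cc2c1`, has not yet been measured. It differs from compound 3 in one place: amino in place of (hexylcarbonyl)oxy on a saturated chain carbon bound to an aromatic carbon. Among the measured compounds shown here, no measured pair touches this position; compounds 1 and 2 carry an acetoxy group there and compound 3 a longer ester, but compound 3 also differs from them on the carbonyl carbon, so the two values of compound 2 and compound 3 cannot be split into one change at a time. For the measured compounds named here, the only step known is of modest size, and nothing argues for a large move in either direction.

Compound 4 is therefore expected to give about 65% in this assay, within 45% to 85%, which would mean an estimated step of a number 9.4 percentage points higher from compound 3 to compound 4 (within the scatter).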

Compound 4, a percentage reported as activity, at one concentration (the size of the read-out at that concentration, not a potency): 79.3%
The estimate for compound 4 lay 14.3 percentage points below the measured number; measured number inside the range.
By their numbers in this assay, from the lowest: compound 3; then compound 2; then compounds 4 and 1 (each within the scatter of the next).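

In this assay, the saturated chain carbon bound to an aromatic carbon proves to be a position that moves the read-out on its own: amino in place of (hexylcarbonyl)oxy gives a number 23.7 percentage points higher from compound 3 to compound 4 (beyond the scatter), the first step recorded here, since the earlier step, a number 16.6 percentage points lower from compound 1 to compound 2 (beyond the scatter), concerned only the group on a carbonyl carbon. The change swaps a group of 9 heavy atoms, with no hydrogen-bond donor, for one of 1 heavy atom that carries 1 hydrogen-bond donor, and in this pair the lower number goes with the ester. Nothing measured in this set explains why the number rises with this exchange.

The compounds shown leave open whether the step follows from the loss of the hexylcarbonyl chain or from the arrival of the amine, since the two come together in this single change. An acetoxy group, a hydroxyl group or a longer ester chain on the same carbon, with the rest of compound 3 kept, would begin to separate the two, as would an acetamide in place of the free amine of compound 4.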